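From 2-methoxyphenyl to 3-chlorophenyl in a weak antiproliferative compound

The source may report more compounds than this note shows. Statements on the series, on what has been measured and on what is new or still open speak of the compounds shown alone.

- Compound 1 `COc1ccccc1OS(=O)(=O)c1ccc(N2CCN(C)C2=O)cc1` measured at 26000 nM
- Compound 2 `Cc1ccc(OS(=O)(=O)c2ccc(N3CCN(C)C3=O)cc2)c(C)c1` measured at 2500 nM
- Compound 3 `CN1CCN(c2ccc(S(=O)(=O)Oc3c(Cl)cc(Cl)cc3Cl)cc2)C1=O` measured at 2900 nM

In a functional assay on MCF7 cells (Homo sapiens) for antiproliferative activity, read by sulforhodamine B assay, with a stated time of 48 h (a higher number here means a weaker inhibitor, a lower number a stronger inhibitor), compound 1 stands at 26000 nM as the weakest of the three, with the highest number. Compound 4 `CN1CCN(c2ccc(S(=O)(=O)Oc3cccc(Cl)c3)cc2)C1=O` has not been measured yet. It keeps the core of compound 1 and carries 3-chlorophenyl in place of 2-methoxyphenyl on an oxygen and the other neighbour of that oxygen is the sulfonyl sulfur.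

Among the measured compounds shown here, one measured step bears on this directly, a large one: a 10-fold lower number from compound 1 to compound 2 (1.02 log units; beyond the scatter) when 2,4-dimethylphenyl replaces 2-methoxyphenyl on the same oxygen. Compound 3 also lacks the 2-methoxyphenyl group and carries chlorine on that ring, and it gives 2900 nM in the same test. For the measured compounds named here, no measured compound carries 3-chlorophenyl itself, so these results are only a guide. Going by compound 2 at 2500 nM and compound 3 at 2900 nM a lower number than for compound 1 is expected in this assay although probably not quite as low. The expected change is a 4.3-fold lower number from compound 1 to compound 4 (0.64 log units; beyond the scatter) and so beyond the scatter. For compound 4 the estimate is 6000 nM with an expected range from 1800 nM to 20000 nM.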

Compound 4, half-maximal inhibitory concentration: 2200 nM
Compound 4: the middle estimate sits 2.7-fold (0.44 log units) above what was measured; the range from low to high includes it.
By their numbers in this assay, from the lowest: compounds 4, 2 and 3 (each within the scatter of the next); then compound 1.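

In this assay, the change to 3-chlorophenyl gives a 12-fold lower number from compound 1 to compound 4 (1.07 log units; beyond the scatter). The earlier low numbers came with the 2,4-dimethylphenyl ring of compound 2 and the more heavily chlorinated ring of compound 3, and this result shows that the plain 3-chlorophenyl ring on the same oxygen does just as well: the swap gives a 1.1-fold lower number from compound 2 to compound 4 (0.06 log units; within the scatter), so compound 2 and compound 4 cannot be told apart in this test. Among these four compounds, only compound 1, the one with 2-methoxyphenyl, stands apart from the rest, while three differently substituted rings give closely matching numbers, and nothing measured here explains why.

On these data alone, it remains open whether the methoxy group itself or its place on the ring sets compound 1 apart, a question that 3-methoxyphenyl or unsubstituted phenyl on this oxygen could help to settle. Also open, as far as these compounds go, is how this antiproliferative activity would respond to a ring carrying an amine or a carboxylic acid, or to a saturated ring such as cyclohexyl in place of the aromatic one.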